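The source may hold more compounds than are shown below. What is called first, only, known or untested is meant among the compounds shown, and "the series" means these compounds.

Measured so far: compound 1 `CSS[C@H]1C[C@H](n2ccc(N)nc2=O)O[C@@H]1CO` with 149000 nM; compound 2 `Cc1cn([C@H]2C[C@H](SSc3ccc([N+](=O)[O-])cc3)[C@@H](CO)O2)c(=O)[nH]c1=O` with 29000 nM; compound 3 `C=CCSS[C@H]1C[C@H](n2cc(C)c(=O)[nH]c2=O)O[C@@H]1CO` with 34000 nM.

In a functional assay on MOLT-4 cells (Homo sapiens) for cytotoxicity (a higher number here means a weaker inhibitor, a lower number a stronger inhibitor), compound 3 gives 34000 nM, the second highest of the three numbers. Its nearest neighbour is compound 2, and the step of a 1.2-fold higher number from compound 2 to compound 3 (0.07 log units; within the scatter) lies within the scatter. Compound 1, with 149000 nM, is the furthest from it and lies beyond the scatter.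

Compound 4 `CCCCCCCCSS[C@H]1C[C@H](n2cc(C)c(=O)[nH]c2=O)O[C@@H]1CO` differs from compound 3 by heptyl in place of vinyl on a saturated chain carbon bound to a sulfur. Among the measured compounds shown here, the only measured step bearing on a change at the sulfur, a 1.2-fold higher number from compound 2 to compound 3 (0.07 log units; within the scatter), was within the scatter, and no measured step lengthens the chain on the sulfur. The expected step of a 1.1-fold lower number from compound 3 to compound 4 (0.05 log units; within the scatter) is therefore none beyond the scatter. Compound 4 is estimated at 30000 nM, between 8000 nM and 110000 nM.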

Compound 4, half-maximal inhibitory concentration: 26000 nM
Compound 4: middle estimate off by 1.2-fold (0.06 log units), on the high side; the range from low to high includes it.
By their numbers in this assay, from the lowest: compounds 4, 2 and 3 (each within the scatter of the next); then compound 1.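

In this assay, a much longer chain on the sulfur changes little: heptyl in place of vinyl gives a 1.3-fold lower number from compound 3 to compound 4 (0.12 log units; within the scatter), and octyl in place of 4-nitrophenyl gives a 1.1-fold lower number from compound 2 to compound 4 (0.05 log units; within the scatter). On this core, the octyl, allyl and 4-nitrophenyl disulfides thus read alike, so neither chain length nor the aromatic ring separates them here. No evidence accompanies this result to account for it. The compounds shown leave open whether an octyl chain ending in an amine or a carboxylic acid would move the number beyond the scatter.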